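From methyl to chloro in compound 3

The source may report more compounds than this note shows. Statements on the series, on what has been measured and on what is new or still open speak of the compounds shown alone.

Measured so far in a functional assay on RS4-11 cells (Homo sapiens) for inhibition, read by CCK-8 assay, with a stated time of 48 h, tested at 20 uM; on this read-out higher numbers stand for more inhibition of growth at the one concentration tested and lower numbers for less inhibition of growth:
Compound 1 `N#C/C(=C\c1ccccc1OS(=O)(=O)c1ccc(Cl)cc1)C(=O)Nc1nnc(-c2cccc(F)c2)s1` gives 71%
Compound 2 `Cc1ccc(S(=O)(=O)Oc2ccccc2/C=C(\C#N)C(=O)Nc2nnc(Cc3ccc(Cl)cc3)s2)cc1` gives 69%

Among the measured compounds shown here, with only two numbers available, there is little to place compound 2 against. In this assay compound 2 gives 69% and compound 1 gives 71%, and the gap between these two values lies within the usual scatter of repeated measurements, so they cannot be told apart.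

Compound 3 `N#C/C(=C\c1ccccc1OS(=O)(=O)c1ccc(Cl)cc1)C(=O)Nc1nnc(Cc2ccc(Cl)cc2)s1` differs from compound 2 in one place (chloro in place of methyl on an aromatic carbon). It has chloro in place of methyl on an aromatic carbon, para to a large group, which turns the (4-methylphenyl)sulfonyl group into a (4-chlorophenyl)sulfonyl group.

For the measured compounds named here, no pair of measured compounds shows this change on its own, so the data give no direct size for it. The two measured values show no spread beyond the scatter, so no step beyond the scatter is expected in this assay, in either direction. The estimated change is small, a step of a number 1 percentage points higher from compound 2 to compound 3 (within the scatter) that would stay inside the scatter. For compound 3 the expected value is 70%, with an estimated range of 55% to 83%.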

Compound 3, percent growth inhibition at one concentration: 64%
Compound 3: the middle estimate sits 6 percentage points above what was measured; the range from low to high includes it.
By their numbers in this assay, from the lowest: compounds 3, 2 and 1 (each within the scatter of the next).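

Among the compounds shown here, compound 3 completes the first pair that differs only in the group on the sulfonyl: in this assay, chloro in place of methyl on the aromatic carbon gives a number 5 percentage points lower from compound 2 to compound 3 (within the scatter) and so shows that, with the 4-chlorobenzyl group kept, methyl and chloro at this position cannot be told apart. It also completes a pair that differs at a second place, where 4-chlorobenzyl in place of 3-fluorophenyl gives a number 7 percentage points lower from compound 1 to compound 3 (within the scatter) and, with the (4-chlorophenyl)sulfonyl group kept, likewise cannot be told apart from no change. No independent evidence is available to explain either step.

From the compounds shown here alone, whether any other group at this position, such as an amine, a methoxy group or a carboxylic acid, would shift growth inhibition beyond the scatter remains open. The single tested concentration also leaves open how these compounds would compare across a range of concentrations, and whether the exchange of methyl for chloro would look the same with the 3-fluorophenyl group in place of the 4-chlorobenzyl group.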